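The compounds below may be only part of what the source reports. "The series", "measured", "known", "first", "only" and "open" are said of these compounds alone.

Of the compounds shown here, three built on one shared core have been measured in a functional assay on KB cells (Homo sapiens) for antiproliferative activity, read by sulforhodamine B assay, with a stated time of 48 h; on this read-out higher numbers stand for weaker inhibition of growth and lower numbers for stronger inhibition of growth. Compound 1 `COc1ccc(Nc2nc(NCCCO)c3ccccc3n2)cc1` gives 20300 nM, compound 2 `CCCNc1nc(Nc2ccc(OC)cc2)nc2ccccc12` gives 5330 nM, and compound 3 `COc1ccc(Nc2nc(NC3CC3)c3ccccc3n2)cc1` gives 13300 nM. Compound 2 has the lowest number of the three: there is a 3.8-fold lower number from compound 1 to compound 2 (0.58 log units; beyond the scatter) and a 2.5-fold higher number from compound 2 to compound 3 (0.40 log units; beyond the scatter), both beyond the scatter, while a 1.5-fold lower number from compound 1 to compound 3 (0.18 log units; within the scatter) stays within it. Compound 4 `CCCNc1nc(Nc2ccc(F)cc2)nc2ccccc12` differs from compound 2 by fluoro in place of methoxy on an aromatic carbon. Among the measured compounds shown here, none of the measured steps touches this part of the molecule; all three vary the other substituent on the core, so they carry no direct information about this change. With nothing to point either way, the step of a 1.1-fold higher number from compound 2 to compound 4 (0.05 log units; within the scatter) is expected to stay within the scatter. Compound 4 is therefore estimated at 6000 nM, with a range from 2000 nM to 18000 nM.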

Compound 4, concentration for 50% growth inhibition: 2900 nM
Beside the measured number, compound 4's estimate is 2.1-fold (0.32 log units) above it, and the stated range covers the measured number.
By their numbers in this assay, from the lowest: compounds 4 and 2 (each within the scatter of the next); then compounds 3 and 1 (each within the scatter of the next).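

In this assay, this is the first change shown at the aromatic carbon para to a large group, and fluoro in place of methoxy gives a 1.8-fold lower number from compound 2 to compound 4 (0.26 log units; within the scatter). Here, with the propyl group held constant, a single fluorine replaces two heavy atoms, one of them a hydrogen-bond acceptor, and the numbers stay within the scatter of each other. Nothing measured here speaks to the reason for this result.

As far as these compounds go, whether chloro, an amine or a carboxylic acid at this position would do the same remains open. So does whether fluoro gives a similar step with cyclopropyl or 3-hydroxypropyl on the nitrogen.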